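The compounds below may be only part of what the source reports. "The series", "measured", "known", "first", "only" and "open" are said of these compounds alone.

In a functional assay on HCT-116 cells (Homo sapiens) for antiproliferative activity, read by MTT assay, with a stated time of 24 h (a lower number here means a stronger inhibitor, a higher number a weaker inhibitor), three compounds sharing one core have been measured. Compound 1 `COc1cccc(/C=C/C(=O)c2ccc(OC)c3c2OC(C)(C)C=C3)c1` gives > 10000 nM, which is a limit and not a number. Compound 2 `COc1ccc(C(=O)/C=C/c2ccc(Br)cc2)c2c1C=CC(C)(C)O2` gives > 10000 nM, also a limit. Going by the values given here, compound 3 `COc1ccc(C(=O)/C=C/c2ccc(N(C)C)cc2)c2c1C=CC(C)(C)O2` gives 1920 nM, the only true number among the three. Compound 4 `COc1ccc(C(=O)/C=C/c2ccc(N3CCCC3)cc2)c2c1C=CC(C)(C)O2` differs from compound 3 in one group: pyrrolidin-1-yl in place of dimethylamino on an aromatic carbon. Two measured steps lead to dimethylamino: an at least 5.2-fold lower number from compound 1 to compound 3 (0.71 log units; beyond the scatter), and an at least 5.2-fold lower number from compound 2 to compound 3 (0.71 log units; beyond the scatter). Neither replaces dimethylamino itself, so neither gives a size for this change. The expected step is therefore none beyond the scatter, estimated as a 1.1-fold lower number from compound 3 to compound 4 (0.03 log units; within the scatter). Compound 4 is expected near 1800 nM, with an estimated range from 600 nM to 6000 nM.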

Compound 4, half-maximal inhibitory concentration: 8590 nM
The estimate for compound 4 lay 4.8-fold (0.68 log units) below the measured number, and the stated range ends below it.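

In this assay, a tertiary amine at this aromatic carbon is not enough to keep the number low: pyrrolidin-1-yl in place of dimethylamino gives a 4.5-fold higher number from compound 3 to compound 4 (0.65 log units; beyond the scatter). So the step gained with dimethylamino does not carry over to pyrrolidin-1-yl. Against bromo, the comparison gives only a floor, an at least 1.1-fold lower number from compound 2 to compound 4 (0.06 log units; that floor lies within the scatter), since one end of it is a limit of the assay: the limit of > 10000 nM in this assay, at which 2 of the 4 values shown sit.

Why the two amines differ stays open. So does where piperidin-1-yl, morpholin-4-yl or diethylamino at this carbon would fall.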